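A few compounds are considered here, and "the series" means these few. Any claim that something is new, unique, unknown or untested is made for them only; others in the source may bear on it.

Working notes on the series. In an ADME assay on PC-3 cells (Homo sapiens) for cytotoxicity, read by WST assay, tested at 100 uM (on this read-out higher numbers stand for more inhibition at the one concentration tested (going by the name of the read-out) and lower numbers for less inhibition), compound 1 `O=C(Nc1cccc(-c2ccco2)c1)C1CCCN(C(=O)c2cc(C(F)(F)F)cc(C(F)(F)F)c2)C1` gives 0%, and stands level with compound 2 `CC(C)(C)CC(=O)Nc1cccc(C(=O)N2CCCC(C(=O)Nc3ccc(Cl)cc3)C2)c1`, which gives 0%, and with compound 3 `CSc1cccc(C(=O)N2CCCC(C(=O)Nc3ccc(Cl)cc3)C2)c1`, which gives 0%. Within the data shown here, the one measured step, no change at the digits printed from compound 2 to compound 3 (within the scatter), concerns another substituent of the shared core and shows no change within the scatter. Compound 4 `C=CCOc1cccc(NC(=O)C2CCCN(C(=O)c3cc(C(F)(F)F)cc(C(F)(F)F)c3)C2)c1` differs from compound 1 by allyloxy in place of furan-2-yl on an aromatic carbon. Among the measured compounds shown here, no measured step covers this exchange of groups, so the expectation rests on the flat behaviour of compounds 1, 2 and 3 in this assay. For compound 4 the expected step is no change at the digits printed from compound 1 to compound 4 (within the scatter), none beyond the scatter. Compound 4 is therefore estimated at 0%, within a range from 0% to 15%.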

Compound 4, a percentage reported as inhibition, at one concentration (the size of the read-out at that concentration, not a potency): 0%
Compound 4: middle estimate and measured number agree at the digits printed; measured number inside the range.
By their numbers in this assay, from the lowest: compounds 1, 2, 3 and 4 (each within the scatter of the next).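

In this assay allyloxy in place of furan-2-yl shows no change at the digits printed from compound 1 to compound 4 (within the scatter) and so gives this position, meta to a large group, a measured step of its own; the earlier step concerned another substituent. At this position, an open chain with a double bond reads the same as a five-membered aromatic ring, so that ring is not needed to hold the read-out at this level. Nothing measured here explains the flat read-out. Going by these compounds, whether any group at this position moves the read-out remains open, for instance an amine or a carboxylic acid.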